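Ring contraction at the amide side chain of compound 1

A few compounds are considered here, and "the series" means these few. Any claim that something is new, unique, unknown or untested is made for them only; others in the source may bear on it.

Of the compounds shown here, three have been measured in an ADME assay on MT4 cells (Homo sapiens) for cytotoxicity, read by MTT assay, with a stated time of 96 h; a higher number here means that more compound is tolerated, a lower number that less compound is tolerated. Compound 1, `O=C(CN1CCCCC1)Nc1ccc(-c2nc3cc(Cl)c(Cl)cc3[nH]2)cc1`, gives 54000 nM. Compound 2, `COc1cc(OC)cc(-c2nc3cc(C(F)(F)F)ccc3[nH]2)c1`, gives 19000 nM. Compound 3, `Nc1ccc(-c2nc3cc(C(F)(F)F)ccc3n2C2CCCCC2)cc1`, gives 44000 nM. Among these three, compound 1 has the highest number, but its gap to compound 3 lies within the usual scatter, so the two cannot be ordered; only compound 2 stands clearly lower, beyond the scatter. Going by the values given here, the three share no single-point relationships, so no step between measured compounds can be read off.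

Compound 4, `O=C(CN1CCCC1)Nc1ccc(-c2nc3cc(Cl)c(Cl)cc3[nH]2)cc1`, has not yet been tested in this assay. It differs from compound 1 in one place: pyrrolidin-1-yl in place of piperidin-1-yl on a saturated chain carbon bound to a carbonyl carbon. Both groups carry no donor, one acceptor and no charge, and the change removes one carbon from a saturated ring on a saturated chain carbon bound to a carbonyl carbon. Among the compounds with values here, nothing among the measured compounds speaks to such a change.

Given that compound 1 gives 54000 nM, the step from compound 1 to compound 4 is expected to be small, most likely within the scatter, with no clear direction, as a 1.1-fold lower number from compound 1 to compound 4 (0.03 log units; within the scatter). For compound 4 the estimate in this assay is 50000 nM, expected to fall between 25000 nM and 100000 nM.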

Compound 4, half-maximal cytotoxic concentration: 8000 nM
For compound 4 the middle estimate is 6.3-fold (0.80 log units) above the measured one; the whole stated range lies above it.
By their numbers in this assay, from the lowest: compound 4; then compound 2; then compounds 3 and 1 (each within the scatter of the next).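

In this assay, a 6.8-fold lower number from compound 1 to compound 4 (0.83 log units; beyond the scatter) shows that this position is sensitive to the size of the saturated ring: pyrrolidin-1-yl in place of piperidin-1-yl moves the number beyond the scatter, although the counts of hydrogen-bond donors and acceptors and the net charge stay the same. Going by these compounds alone, the earlier compounds share no single-point relationship, so they could say nothing about a change on a saturated chain carbon bound to a carbonyl carbon, and this pair gives the first step that can be read. Nothing at hand explains why the five-membered ring gives so much lower a number than the six-membered ring here. Whether the step follows ring size in a regular way remains open, as the compounds shown do not include azepan-1-yl, morpholin-4-yl or an open-chain amine such as dimethylamino at this place. As far as these compounds go, it also remains open whether the same change would give a similar step on a different core, as this single pair is all that speaks for it.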